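Larger ring group back in place of methyl

A few compounds are considered here, and "the series" means these few. Any claim that something is new, unique, unknown or untested is made for them only; others in the source may bear on it.

Among the measured compounds shown here, compound 2 `Cc1cc(-c2cnn(C3CCNCC3)c2)on1` stands at the higher end of the two numbers measured so far: in an assay on isolated protein for positive allosteric modulation of Neuronal acetylcholine receptor; alpha4/beta2 (Homo sapiens) (a higher number here means that more compound is needed for the effect, a lower number that less compound is needed), compound 2 gives 1300 nM, whereas compound 1 `Clc1ccccc1-c1cc(-c2cnn(C3CCNCC3)c2)on1` gives 120 nM. For the measured compounds named here, the one measured step that bears on the next change is an 11-fold higher number from compound 1 to compound 2 (1.03 log units; beyond the scatter), a large shift when a large group gave way to methyl. Compound 3 `c1nn(C2CCNCC2)cc1-c1cc(C2CCCCC2)no1` differs from compound 2 by cyclohexyl in place of methyl on an aromatic carbon, so a large group returns at the same place, here a saturated ring rather than a substituted aromatic one. Going by the values given here, the measured step ran the other way with a group of comparable heavy-atom count, so a step of similar size toward a lower number is expected in this assay, though only a single step supports this and the two large groups are not alike. Compound 3 is therefore estimated at 250 nM in this assay, with a range from 80 nM to 800 nM. That estimate means a 5.2-fold lower number from compound 2 to compound 3 (0.72 log units; beyond the scatter).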

Compound 3, half-maximal effective concentration: 4600 nM
Beside the measured number, compound 3's estimate is 18-fold (1.26 log units) below it; measured number outside the range, above it.
By their numbers in this assay, from the lowest: compound 1; then compound 2; then compound 3.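

In this assay, a large group at this aromatic carbon does not by itself give a lower number: cyclohexyl in place of methyl gives a 3.5-fold higher number from compound 2 to compound 3 (0.55 log units; beyond the scatter). The two large groups also lie far apart, with a 38-fold higher number from compound 1 to compound 3 (1.58 log units; beyond the scatter), so methyl falls between them in the order of the three compounds, and 2-chlorophenyl and cyclohexyl cannot be treated as interchangeable at this place. Nothing at hand gives a reason for this order.

The compounds shown leave open whether the low number of compound 1 goes with the aromatic ring as such or with its chlorine, a question that unsubstituted phenyl would address. Also open, on these data alone, is where a smaller saturated ring such as cyclopropyl, or a nitrogen-containing aromatic ring such as pyridyl, would fall in this order.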